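Phenyl for Fluoro: Expected Tolerance of Compound 4

This account rests on a few compounds, and the source may have more. Where it says the series, first, only, none or still open, it means among the compounds named here.

This account follows the step from compound 3 `CO[C@@H]1[C@@H](OC)[C@H](c2ccccc2)O[C@@H]2CO[C@@H](c3ccc(F)cc3)O[C@@H]12` to compound 4 `CO[C@@H]1[C@@H](OC)[C@H](c2ccccc2)O[C@@H]2CO[C@@H](c3ccc(-c4ccccc4)cc3)O[C@@H]12`. Compound 3 has no single number in a functional assay on HEL cells (Homo sapiens) for cytotoxicity; a lower number here means that less compound is tolerated, a higher number that more compound is tolerated; its entry there reads "not determined" (no result reported). Compound 1 `COc1ccc([C@@H]2OC[C@H]3O[C@@H](c4ccccc4)[C@H](OC)[C@@H](OC)[C@@H]3O2)cc1` likewise shows "not determined" (no result reported) in this assay. Compound 2 `CO[C@@H]1[C@@H](OC)[C@H](c2ccccc2)O[C@@H]2CO[C@@H](c3ccc(Cl)cc3)O[C@@H]12` gives only a limit of the assay, >= 100 ug/mL in this assay. Among the compounds with values here, the one piece of evidence is that limit: the limit of >= 100 ug/mL in this assay, at which 1 of the 3 values shown sits. Compound 4 differs from compound 3 by phenyl in place of fluoro on an aromatic carbon. No step between measured compounds is shown, so one expects the change from compound 3 to compound 4 in this assay to be either within the scatter or a modest step toward less compound tolerated. For compound 4 in this assay the expected value is 100 ug/mL, with a range from 25 ug/mL to 200 ug/mL.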

Compound 4, minimum cytotoxic concentration: >= 16 ug/mL
Compound 4: no number, only a limit (the forecaster's own chance of this, stated with the estimate: 60%); the middle value is on the limit's open side.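

Within the data shown here, compound 2 and compound 4 each carry only a limit in this assay, and no step between them can be read. The compounds shown leave open whether phenyl in place of chloro changes the tolerated concentration at all.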